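Compound 3: piperidin-1-yl on the saturated chain carbon

This account rests on a few compounds, and the source may have more. Where it says the series, first, only, none or still open, it means among the compounds named here.

In an in vitro ADME assay on microsomes from liver (Homo sapiens) for metabolic stability (on this read-out lower numbers stand for slow clearance and higher numbers for fast clearance), compound 2 (`CC(C)NC(=O)[C@H]1CC[C@@H](n2/c(=N/C(=O)c3ccc(F)cc3)[nH]c3ccc(CN4CC(C(C)(C)O)C4)cc32)CC1`) gives 105 mL.min-1.g-1 and lies within the scatter of compound 1 (`CC(C)NC(=O)[C@H]1CC[C@@H](n2/c(=N/C(=O)c3ccccc3)[nH]c3ccc(CN4CCCCC4)cc32)CC1`) at 203 mL.min-1.g-1 on this read-out. Compound 3 (`CC(C)NC(=O)[C@H]1CC[C@@H](n2/c(=N/C(=O)c3ccc(F)cc3)[nH]c3ccc(CN4CCCCC4)cc32)CC1`) has piperidin-1-yl in place of 3-(1-hydroxy-1-methylethyl)azetidin-1-yl on a saturated chain carbon bound to an aromatic carbon. For the measured compounds named here, no measured step covers this change. Compound 1 also carries piperidin-1-yl and gives 203 mL.min-1.g-1 in this assay so a modest rise towards faster clearance, near the edge of the scatter, is expected. The step expected is a 1.8-fold higher number from compound 2 to compound 3 (0.26 log units; within the scatter) on this read-out. Compound 3 is expected at 190 mL.min-1.g-1 with an estimated range from 110 mL.min-1.g-1 to 320 mL.min-1.g-1 in this assay once measured.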

Compound 3, intrinsic clearance in microsomes: 302 mL.min-1.g-1
Compound 3: the middle estimate sits 1.6-fold (0.20 log units) below what was measured; the measured number falls inside the stated range.
By their numbers in this assay, from the lowest: compounds 2, 1 and 3 (each within the scatter of the next, the first and the last beyond it).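

In this assay, piperidin-1-yl in place of 3-(1-hydroxy-1-methylethyl)azetidin-1-yl on a saturated chain carbon bound to an aromatic carbon gives a 2.9-fold higher number from compound 2 to compound 3 (0.46 log units; beyond the scatter) and so moves this read-out beyond the scatter. Fluoro in place of hydrogen on an aromatic carbon gives a 1.5-fold higher number from compound 1 to compound 3 (0.17 log units; within the scatter) and so does not separate that pair. Nothing available bears on the reason for the step at the saturated chain carbon.

Open, as far as these compounds go, is which part of the departing group carries the step, the four-membered ring or its hydroxyl-bearing substituent. A 4-hydroxypiperidin-1-yl on the same carbon would separate the two.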